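This account rests on a few compounds, and the source may have more. Where it says the series, first, only, none or still open, it means among the compounds named here.

Compound 1 `CNC(=O)c1cc(Oc2ccc(C(=O)/C=C/c3ccc(F)cc3Cl)cc2)ccn1`: 7320 nM
Compound 2 `CNC(=O)c1cc(Oc2ccc(C(=O)/C=C/c3ccc(F)cc3)cc2)ccn1`: 12600 nM

Among the measured compounds shown here, only two numbers are available so far from a functional assay on HepG2 cells (Homo sapiens) for cytotoxicity, read by MTT assay, with a stated time of 72 h; a lower number here means a stronger inhibitor, a higher number a weaker inhibitor. Compound 2 gives 12600 nM, which cannot be told apart from the value of compound 1, 7320 nM. Compound 3 `CNC(=O)c1cc(Oc2ccc(C(=O)/C=C/c3cccc([N+](=O)[O-])c3)cc2)ccn1` is the next compound to consider, and it starts from compound 2 with this change: 3-nitrophenyl in place of 4-fluorophenyl on a double-bonded chain carbon bound to a double-bonded chain carbon. In words, 3-nitrophenyl takes the place of 4-fluorophenyl on a double-bonded chain carbon bound to a double-bonded chain carbon.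

For the measured compounds named here, one measured step bears on this, and only indirectly: a 1.7-fold higher number from compound 1 to compound 2 (0.24 log units; within the scatter). There, hydrogen replaces chloro on an aromatic carbon of the group that leaves in compound 3. Going by the values given here, that change is smaller than the new one, and no measured compound carries 3-nitrophenyl. A single step within the scatter gives no direction, so no step beyond the scatter is expected, though the uncertainty stays wide. The estimated step is a 1.1-fold lower number from compound 2 to compound 3 (0.06 log units; within the scatter). For compound 3 the expected value is 11000 nM, with an estimated range of 4500 nM to 28000 nM.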

Compound 3, half-maximal inhibitory concentration: > 50000 nM
Compound 3: only a limit was reported (the forecaster's own chance of this, stated with the estimate: 8%); at least 4.5-fold (0.65 log units) between middle value and limit.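

Compound 3 is reported in this assay only as a limit: the limit of > 50000 nM in this assay, at which 1 of the 3 values shown sits.

Even so, the step can be read, and the change of 4-fluorophenyl to 3-nitrophenyl on a double-bonded chain carbon gives an at least 3.9-fold higher number from compound 2 to compound 3 (0.59 log units; beyond the scatter), a clear loss of inhibition in this assay. The comparison with the chlorinated compound points the same way, with an at least 6.8-fold higher number from compound 1 to compound 3 (0.83 log units; beyond the scatter), whereas the earlier swap of chloro for hydrogen on that ring stayed within the scatter, so this position can respond to a change of group in a way the first two compounds did not reveal.

The compounds shown do not separate the loss of the fluorine from the arrival of the nitro group, as both happen in the same step and no compound carries a plain phenyl group at this place. From the compounds shown here alone, whether the step belongs to the nitro group itself also stays open, and an amine or a nitrile in its place on the same ring would bear on that question.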